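A few compounds are considered here, and "the series" means these few. Any claim that something is new, unique, unknown or untested is made for them only; others in the source may bear on it.

Two compounds have numbers in an ADME assay on HepG2 2.2.15 cells (Homo sapiens) for cytotoxicity, read by MTT assay; a lower number here means that less compound is tolerated, a higher number that more compound is tolerated. Compound 1 (`CC(=O)c1ccc(OC(=O)c2cccnc2)cc1`) gives 3010000 nM and compound 2 (`CC(=O)c1ccc(O[C@@H]2O[C@H](COC(=O)/C=C/c3ccc(F)c(F)c3)[C@@H](O)[C@H](O)[C@H]2O)cc1`) gives 874000 nM, the lower of the two and separated from compound 1 by more than the usual scatter. Compound 3 (`CC(=O)c1ccc(O[C@@H]2O[C@H](COC(=O)c3cccs3)[C@@H](O)[C@H](O)[C@H]2O)cc1`) has not yet been measured. It differs from compound 2 in one place, with thiophen-2-yl in place of 2-(3,4-difluorophenyl)ethenyl on a carbonyl carbon. Going by the values given here, no step between measured compounds that differ in one place is available as a guide, so the expectation rests on the two values alone. A small rise is expected, close to or within the scatter, with compound 1 at 3010000 nM as a rough upper guide. The expected change is a 1.6-fold higher number from compound 2 to compound 3 (0.20 log units; within the scatter). The estimate for compound 3 is 1400000 nM, with an expected range from 600000 nM to 3500000 nM.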

Compound 3, half-maximal cytotoxic concentration: 1570000 nM
For compound 3 the middle estimate is 1.1-fold (0.05 log units) below the measured one; low and high end bracket the measured number.
By their numbers in this assay, from the lowest: compounds 2, 3 and 1 (each within the scatter of the next, the first and the last beyond it).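

In this assay, the exchange of 2-(3,4-difluorophenyl)ethenyl for thiophen-2-yl on a carbonyl carbon gives a 1.8-fold higher number from compound 2 to compound 3 (0.25 log units; within the scatter). Going by these compounds alone, this is the first one-place comparison, and it shows that a group of 10 heavy atoms with a six-membered aromatic ring and a double bond, and one of 5 heavy atoms with a five-membered aromatic ring containing sulfur, read within the scatter of each other at this position. Nothing measured here offers an explanation for this result.

The two groups are both aromatic, so the compounds shown leave open how a plain phenyl ring, a saturated alkyl chain, an amine or a carboxylic acid on the same carbonyl carbon would read. They also leave open whether any change elsewhere on the shared core would move the number beyond the scatter.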